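Biaryl anilides: removing one amide for trifluoromethyl

This account rests on a few compounds, and the source may have more. Where it says the series, first, only, none or still open, it means among the compounds named here.

Compound 1 `O=C(Nc1cccc(-c2cccc(NC(=O)C(Cl)Cl)c2)c1)C(Cl)Cl` carries a ((dichloromethyl)carbonyl)amino group on each ring of its core and gives 47900 nM in a functional assay on A549 cells (Homo sapiens) for cytotoxicity, read by MTT assay, with a stated time of 68 h (on this read-out higher numbers stand for weaker inhibition and lower numbers for stronger inhibition), the highest number among the three measured here. Compound 2 `COc1cccc(-c2cc(NC(=O)C(Cl)Cl)cc(-c3cccc(OC)c3)c2)c1` gives 9400 nM and compound 3 `CC(C)Oc1ccc(-c2cc(NC(=O)C(Cl)Cl)cc(-c3ccc(OC(C)C)cc3)c2)cc1` gives 3820 nM; both gaps to compound 1 lie beyond the usual scatter, so compound 1 is the weakest inhibitor of the set. Compound 4 `O=C(Nc1cccc(-c2cccc(C(F)(F)F)c2)c1)C(Cl)Cl` is not yet measured; it differs from compound 1 in one place: trifluoromethyl in place of ((dichloromethyl)carbonyl)amino on an aromatic carbon. Among the compounds with values here, no measured pair shares this change, so its size is uncertain; the step expected here is a 1.9-fold lower number from compound 1 to compound 4 (0.28 log units; within the scatter), a modest move toward a lower number that may not clear the scatter. Compound 4 is accordingly estimated at 25000 nM, with a range from 7000 nM to 90000 nM.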

Compound 4, half-maximal inhibitory concentration: 18500 nM
Compound 4: middle estimate off by 1.4-fold (0.13 log units), on the high side; low and high end bracket the measured number.
By their numbers in this assay, from the lowest: compound 3; then compounds 2 and 4 (each within the scatter of the next); then compound 1.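

At this aromatic carbon of the core of compound 1, meta to a large group, the ((dichloromethyl)carbonyl)amino group is not needed for the activity seen in this assay: trifluoromethyl in its place gives a 2.6-fold lower number from compound 1 to compound 4 (0.41 log units; beyond the scatter) and no loss. One of the two identical amide groups can therefore go, taking its hydrogen-bond donor and acceptor with it. No available measurement gives a reason for this step. Going by these compounds, whether the remaining ((dichloromethyl)carbonyl)amino group can also be replaced stays open, as does whether a nitrile or a carboxylic acid at this carbon would match trifluoromethyl.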